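Furan-2-yl for Thiophen-2-yl: A Cytotoxicity Estimate

A few compounds are considered here, and "the series" means these few. Any claim that something is new, unique, unknown or untested is made for them only; others in the source may bear on it.

Going by the values given here, compound 2 `Oc1cccc(-c2cc(-c3cccc(Cl)c3)nc(-c3cccs3)c2)c1` gives 3150 nM in an ADME assay on HEK293 cells (Homo sapiens) for cytotoxicity, read by CCK-8 assay and cell counting, with a stated time of 2 days (on this read-out lower numbers stand for stronger inhibition and higher numbers for weaker inhibition), the lowest of the two numbers available so far. Among the compounds with values here, its nearest neighbour is compound 1 `Oc1cccc(-c2cc(-c3ccc(Cl)cc3)nc(-c3cccs3)c2)c1`, which in this assay gives 11800 nM; the only measured step, a 3.7-fold lower number from compound 1 to compound 2 (0.57 log units; beyond the scatter), arises from a 3-chlorophenyl in place of a 4-chlorophenyl on an aromatic carbon.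

Compound 3 `Oc1cccc(-c2cc(-c3cccc(Cl)c3)nc(-c3ccco3)c2)c1` differs from compound 2 by furan-2-yl in place of thiophen-2-yl on an aromatic carbon. Within the data shown here, no measured step bears on this exchange: the single recorded step concerns the chlorophenyl group and says nothing about the five-membered aromatic ring with 1 hetero atom. The expectation for this assay therefore rests on the modest extent of the change alone, one hetero atom for another in a ring of the same size, and no step beyond the scatter is expected in either direction. Compound 3 is estimated at 3150 nM, with a range from 1500 nM to 6600 nM, an expected step of no change at the digits printed from compound 2 to compound 3 (within the scatter).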

Compound 3, half-maximal inhibitory concentration: 2530 nM
Compound 3: the middle estimate sits 1.2-fold (0.10 log units) above what was measured; measured number inside the range.
By their numbers in this assay, from the lowest: compounds 3 and 2 (each within the scatter of the next); then compound 1.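

Furan-2-yl in place of thiophen-2-yl, on the aromatic carbon next to the ring nitrogen, gives a 1.2-fold lower number from compound 2 to compound 3 (0.10 log units; within the scatter) in this assay. Exchanging one hetero atom of the five-membered aromatic ring for another at this position therefore leaves the read-out within the scatter, whereas the chlorophenyl exchange gave a 3.7-fold lower number from compound 1 to compound 2 (0.57 log units; beyond the scatter) and remains the only step beyond it among these three compounds. No measurement is available that explains either outcome.

From the compounds shown here alone, whether the number would hold with an amine, a carboxylic acid or a plain phenyl ring at this position remains open. So does whether furan-2-yl would give a similar step alongside the 4-chlorophenyl group of compound 1.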